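From Methoxy to Methylsulfanyl on a Shared Nucleoside Core

The source may report more compounds than this note shows. Statements on the series, on what has been measured and on what is new or still open speak of the compounds shown alone.

Compound 1, `COc1ncnc2c1c(-c1ccsc1)cn2[C@@H]1O[C@H](CO)[C@@H](O)[C@H]1O`, gives 3450 nM
Compound 2, `COc1ncnc2c1c(-c1cccs1)cn2[C@@H]1O[C@H](CO)[C@@H](O)[C@H]1O`, gives 6200 nM
Compound 3, `COc1ncnc2c1c(I)cn2[C@@H]1O[C@H](CO)[C@@H](O)[C@H]1O`, gives 14800 nM

In a functional assay on K562 cells (Homo sapiens), read by MTT assay, with a stated time of 72 h (a higher number here means a weaker inhibitor, a lower number a stronger inhibitor), compound 1 holds the lowest of the three numbers. Compound 2 stays within the scatter of compound 1: a 1.8-fold higher number from compound 1 to compound 2 (0.25 log units; within the scatter). Compound 3 lies further off: a 4.3-fold higher number from compound 1 to compound 3 (0.63 log units; beyond the scatter), and likewise a 2.4-fold higher number from compound 2 to compound 3 (0.38 log units; beyond the scatter). Within the data shown here, compound 4, `CSc1ncnc2c1c(-c1ccsc1)cn2[C@@H]1O[C@H](CO)[C@@H](O)[C@H]1O`, keeps the thiophen-3-yl of compound 1 and alters only one group: methylsulfanyl in place of methoxy on an aromatic carbon. Among the measured compounds shown here, none of the measured steps touches this spot; all three exchange a group on a different aromatic carbon of the shared core, so the measured data say nothing about swapping methoxy for methylsulfanyl. Compound 4 is therefore expected to land close to compound 1, with no step beyond the scatter: a 1.1-fold lower number from compound 1 to compound 4 (0.03 log units; within the scatter). The estimate for compound 4 is 3200 nM, from 1000 nM to 10000 nM.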

Compound 4, half-maximal inhibitory concentration: > 20000 nM
Compound 4: a limit, no number (the forecaster's own chance of this, stated with the estimate: 5%); middle value at least 6.2-fold (0.79 log units) away from the limit.
By their numbers in this assay, from the lowest: compounds 1 and 2 (each within the scatter of the next); then compound 3. At a limit, above all of these: compound 4.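

In this assay, the group on the aromatic carbon next to the ring nitrogen matters: methylsulfanyl in place of methoxy gives an at least 5.7-fold higher number from compound 1 to compound 4 (0.76 log units; beyond the scatter). Among these compounds, all the earlier steps changed a different aromatic carbon, so this is the first sign that this spot responds to change, even to a swap of one oxygen for one sulfur. The value of compound 4 is a limit, not a number: the limit of > 20000 nM in this assay, at which 1 of the 4 values shown sits.

As far as these compounds go, how much higher the true number of compound 4 lies stays open. So does what an amine or a longer chain such as ethoxy would do at this carbon, and whether methylsulfanyl has the same effect alongside the thiophen-2-yl of compound 2.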